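This account rests on a few compounds, and the source may have more. Where it says the series, first, only, none or still open, it means among the compounds named here.

Measured compounds:
- compound 1 `Oc1cc(C(F)(F)F)ccc1-c1nc(-c2ccccc2O)n(-c2ccc(C(F)(F)F)cc2)n1`: in a functional assay on PC-12 cells (Rattus norvegicus) for cytotoxicity, read by MTT assay, with stated times of 2 h and 24 h, tested at 1 uM (a lower number here means a weaker effect, a higher number a stronger effect of the compound at the concentration tested), compound 1 gives 70.7%
- compound 2 `Oc1cc(C(F)(F)F)ccc1-c1nc(-c2ccccc2O)n(-c2cccc(F)c2)n1`: compound 2 gives 67.2%
- compound 3 `Oc1cc(C(F)(F)F)ccc1-c1nc(-c2ccccc2O)n(-c2ccc(Cl)cc2Cl)n1`: compound 3 gives 69%

All three share the same core and differ only in the aryl group on the aromatic nitrogen. Compound 3 sits close to both neighbours: the step from compound 1 to compound 3 is a number 1.7 percentage points lower from compound 1 to compound 3 (within the scatter) and the step from compound 2 to compound 3 is a number 1.8 percentage points higher from compound 2 to compound 3 (within the scatter), both within the scatter, so on the numbers shown the three compounds cannot be told apart.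

Compound 4 `Cc1cc(C)cc(-n2nc(-c3ccc(C(F)(F)F)cc3O)nc2-c2ccccc2O)c1` is the next member of this set. Its change from compound 3 is 3,5-dimethylphenyl in place of 2,4-dichlorophenyl on an aromatic nitrogen.

The relevant precedent is the whole set of aryl swaps at this position: a number 3.5 percentage points lower from compound 1 to compound 2 (within the scatter), a number 1.7 percentage points lower from compound 1 to compound 3 (within the scatter) and a number 1.8 percentage points higher from compound 2 to compound 3 (within the scatter). Each of them stays within the scatter, whether the entering group carries fluorine, chlorine or trifluoromethyl. On that basis the expected step from compound 3 to compound 4, a number 1 percentage points lower from compound 3 to compound 4 (within the scatter), is none beyond the scatter. Compound 4 is therefore estimated at 68% in this assay, with a range from 57% to 78%.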

Compound 4, a percentage reported as activity, at one concentration (the size of the read-out at that concentration, not a potency): 76.9%
For compound 4 the middle estimate is 8.9 percentage points below the measured one; measured number inside the range.
By their numbers in this assay, from the lowest: compounds 2, 3, 1 and 4 (each within the scatter of the next).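

In this assay the position on the aromatic nitrogen now also accepts 3,5-dimethylphenyl, whose substituents are carbon only, whereas every earlier aryl group carried fluorine, chlorine or trifluoromethyl. Replacing the halogenated groups gives a number 7.9 percentage points higher from compound 3 to compound 4 (within the scatter) and a number 9.7 percentage points higher from compound 2 to compound 4 (within the scatter) and a number 6.2 percentage points higher from compound 1 to compound 4 (within the scatter), so halogen on this aryl group is not required for a reading in the range of the series, and the four compounds cannot be ranked against one another on these numbers. No available measurement accounts for the readings at this position.

As far as these compounds go, all four groups at this position are phenyl rings with halogen, trifluoromethyl or methyl substituents, so it remains open whether an amine or a carboxylic acid on that ring, or a longer alkyl chain in place of the ring, would give a step beyond the scatter. Each value is also a single read-out at one concentration, which gives the size of the effect at that concentration only, and the two hydroxyl groups of the shared core stay constant throughout, so their contribution cannot be read.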